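Urea in place of benzyl on the ring amine

A few compounds are considered here, and "the series" means these few. Any claim that something is new, unique, unknown or untested is made for them only; others in the source may bear on it.

The shared core carries a primary carboxamide and a benzoylamino group on a fused two-ring system; compound 1 `NC(=O)c1c(NC(=O)c2ccccc2Cl)sc2c1CCN(Cc1ccc(Cl)cc1)C2` bears a 4-chlorobenzyl on the ring amine. In a functional assay on HeLa cells (Homo sapiens) for antiproliferative activity, with a stated time of 24 h (on this read-out higher numbers stand for weaker inhibition and lower numbers for stronger inhibition), compound 1 gives > 50000 nM, which is a limit of the assay and not a number. Compound 2 `NC(=O)c1c(NC(=O)c2ccc(C(F)(F)F)cc2)sc2c1CCN(Cc1ccc(Cl)cc1)C2` in this assay gives > 50000 nM, again a limit. The step that the two limits leave unreadable from compound 1 to compound 2 is therefore not readable, and the limit of > 50000 nM in this assay, at which 2 of the 3 values shown sit, holds two of the three values. Within the data shown here, compound 3 `NC(=O)c1c(NC(=O)c2ccccc2Cl)sc2c1CCN(C(=S)Nc1ccccc1C(F)(F)F)C2` is the only compound with a measured number, giving 26700 nM in this assay. Compound 4 `NC(=O)c1c(NC(=O)c2ccccc2Cl)sc2c1CCN(C(=O)Nc1c(Cl)cccc1Cl)C2` differs from compound 1 by (2,6-dichlorophenyl)carbamoyl in place of 4-chlorobenzyl on an amine nitrogen in a ring. Among the measured compounds shown here, no measured step covers a change on the ring amine, so no size can be read for this step; compound 3, the one compound with a thiocarbamoyl on that nitrogen, is the nearest point of reference. Compound 4 is therefore estimated to sit near that reference, at 30000 nM with a range of 8000 nM to 50000 nM, which would mean an expected step of an at least 1.6-fold lower number from compound 1 to compound 4 (0.22 log units; that floor lies within the scatter).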

Compound 4, half-maximal inhibitory concentration: 27200 nM
For compound 4 the middle estimate is 1.1-fold (0.04 log units) above the measured one; measured number inside the range.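

Among these compounds, on the amine nitrogen in the ring, (2,6-dichlorophenyl)carbamoyl in place of 4-chlorobenzyl gives the first step at this position with any readable size: in this assay there is an at least 1.8-fold lower number from compound 1 to compound 4 (0.26 log units; that floor lies within the scatter). With this carbonyl group on the nitrogen compound 4 gives 27200 nM, and with a thiocarbamoyl group there compound 3 gives 26700 nM, so both values are measured numbers. The value of compound 1 is still a limit and not a number, so the step has only a floor: the limit of > 50000 nM in this assay, at which 2 of the 4 values shown sit.

The compounds shown leave open whether the carbonyl, the nitrogen hydrogen or the 2,6-dichlorophenyl ring accounts for the value of compound 4. They also leave open how an acetyl group, a piperidine or a longer alkyl chain on the ring amine would read in this assay.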